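Methyl triazole esters with aryl substituents: step to compound 4

This account rests on a few compounds, and the source may have more. Where it says the series, first, only, none or still open, it means among the compounds named here.

The series shares a methyl ester on a triazole carrying a methyl group and an aryl ring. In a functional assay on NCI-H226 cells (Homo sapiens) for inhibition, read by MTT assay, with a stated time of 72 h (a higher number here means a weaker inhibitor of growth, a lower number a stronger inhibitor of growth), compound 1 `COC(=O)c1nc(C)n(-c2ccccc2C(F)(F)F)n1` gives 6130 nM, and compound 2 `COC(=O)c1nc(C)n(-c2cccc(Br)c2)n1` gives 7350 nM in this assay. Compound 3 `COC(=O)c1nc(C)n(-c2ccc(C(F)(F)F)cc2)n1` gives 16600 nM in this assay, the highest number of the three; its gap to compound 2 and to compound 1 lies beyond the usual scatter, so compound 3 is the weakest growth inhibitor of the measured set.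

Compound 4 `COC(=O)c1nc(C)n(-c2ccc(F)cc2)n1` has not been measured in this assay. It differs from compound 3 by fluoro in place of trifluoromethyl on an aromatic carbon, the place being on an aromatic carbon of a six-membered aromatic ring of carbon only, para to a large group. For the measured compounds named here, no measured pair shows this exact exchange, so the expected step is modest: a small decrease in the number, of a size that stays within the scatter, is expected as a 1.5-fold lower number from compound 3 to compound 4 (0.18 log units; within the scatter). Compound 4 is therefore estimated at 11000 nM in this assay, within a range from 4000 nM to 30000 nM.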

Compound 4, concentration for 50% growth inhibition: 11700 nM
Estimate against measurement, compound 4: 1.1-fold (0.03 log units) below; low and high end bracket the measured number.
By their numbers in this assay, from the lowest: compounds 1, 2, 4 and 3 (each within the scatter of the next, the first and the last beyond it).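

In this assay, for the compounds shown here, fluoro in place of trifluoromethyl on an aromatic carbon, para to a large group, gives a 1.4-fold lower number from compound 3 to compound 4 (0.15 log units; within the scatter), the first exchange that can be read at a single place. At this position, the two groups therefore cannot be told apart in this growth read-out, and the exchange offers no measurable gain or loss on its own. Nothing at hand explains this similarity or links it to any property of either group.

As far as these compounds go, with only fluoro and trifluoromethyl compared here, it remains open whether an amine, a carboxylic acid or a longer chain at the same aromatic carbon would move the number beyond the scatter. Also open, from the compounds shown here alone, is whether the result would hold if a carboxylic acid or an amide replaced the methyl ester on the shared core.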